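A Larger Ring at the End of the Chain

A few compounds are considered here, and "the series" means these few. Any claim that something is new, unique, unknown or untested is made for them only; others in the source may bear on it.

Three compounds share one core and differ only in the group at the end of a short saturated chain. Compound 1 `CCCCNc1nc(N)nc(C)c1CCCCc1ccccc1` gives 857 nM in an assay on HEK293 cells for agonist activity at Toll-like receptor 8 (Homo sapiens), read by spectrophotometry; on this read-out lower numbers stand for an effect already at smaller amounts and higher numbers for an effect only at larger amounts of compound. Compound 2 `CCCCNc1nc(N)nc(C)c1CCCC(C)(C)O` gives 1220 nM in this assay, and compound 3 `CCCCNc1nc(N)nc(C)c1CCCC` gives 780 nM in this assay. The spread is narrow: a 1.4-fold higher number from compound 1 to compound 2 (0.15 log units; within the scatter), a 1.1-fold lower number from compound 1 to compound 3 (0.04 log units; within the scatter) and a 1.6-fold lower number from compound 2 to compound 3 (0.19 log units; within the scatter). Compound 3 therefore stands at one edge of a group whose members cannot be told apart on these numbers.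

Compound 4 `CCCCNc1nc(N)nc(C)c1CCCN1CCCCCC1` has not yet been measured. It differs from compound 3 by azepan-1-yl in place of methyl on a saturated chain carbon, three bonds along the chain from an aromatic carbon. All three measured steps exchange the group on the saturated chain carbon three bonds along the chain from an aromatic carbon, and none of them moved the number beyond the scatter; none of them, however, brought in a ring containing nitrogen. The expectation is therefore a step that stays within the scatter, estimated as a 1.4-fold lower number from compound 3 to compound 4 (0.15 log units; within the scatter). For compound 4 the estimated value in this assay is 550 nM, with a range from 150 nM to 2000 nM.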

Compound 4, half-maximal effective concentration: 178 nM
Estimate against measurement, compound 4: 3.1-fold (0.49 log units) above, and the stated range covers the measured number.
By their numbers in this assay, from the lowest: compound 4; then compounds 3, 1 and 2 (each within the scatter of the next).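

At the saturated chain carbon three bonds along the chain from an aromatic carbon, azepan-1-yl is the only exchange shown in this assay that goes beyond the scatter: a 4.4-fold lower number from compound 3 to compound 4 (0.64 log units; beyond the scatter), a 6.9-fold lower number from compound 2 to compound 4 (0.84 log units; beyond the scatter) and a 4.8-fold lower number from compound 1 to compound 4 (0.68 log units; beyond the scatter). This position therefore responds to what sits on it, even though the methyl, benzyl and 1-hydroxy-1-methylethyl ends could not be told apart, and azepan-1-yl alone brings a seven-membered non-aromatic ring with a nitrogen. Nothing measured here says what about azepan-1-yl lies behind these steps.

Going by these compounds, whether the ring, its nitrogen or both matter remains open. Cycloheptyl would set the ring apart from the nitrogen, while piperidin-1-yl and diethylamino would test ring size and the need for a ring at all.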